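The compounds below may be only part of what the source reports. "The series", "measured", "known", "first", "only" and "open" are said of these compounds alone.

Series notes. In a functional assay on MGC-803 cells (Homo sapiens) for inhibition, read by MTT assay, with a stated time of 48 h (on this read-out lower numbers stand for stronger inhibition and higher numbers for weaker inhibition), compound 1 `Cc1ccc(NC(=S)NC(=O)c2ccc(OCc3ccccc3F)cc2)cc1-c1nc2ccccc2[nH]1` gives 3070 nM and compound 2 `Cc1ccc(COc2ccc(C(=O)NC(=S)Nc3ccc(C)c(-c4nc5ccccc5[nH]4)c3)cc2)cc1` gives 4980 nM. Among the compounds with values here, compound 2 has the highest of the two numbers measured so far, but the only step recorded, a 1.6-fold higher number from compound 1 to compound 2 (0.21 log units; within the scatter), is within the scatter, so no order between compound 1 and compound 2 can be claimed. The next member, compound 3 `Cc1ccc(NC(=S)NC(=O)c2ccc(OCc3cccc(F)c3)cc2)cc1-c1nc2ccccc2[nH]1`, differs from compound 2 in one place: 3-fluorophenyl in place of 4-methylphenyl on a saturated chain carbon bound to an oxygen on an aromatic ring. Within the data shown here, the single measured step that bears on this change is a 1.6-fold higher number from compound 1 to compound 2 (0.21 log units; within the scatter); it exchanges one fluorophenyl for the methylphenyl and stays within the scatter. The move to compound 3 reverses that kind of exchange, so the expected step of a 1.5-fold lower number from compound 2 to compound 3 (0.17 log units; within the scatter) is toward a slightly lower number, and not beyond the scatter. Compound 3 is estimated at 3400 nM in this assay, with a range from 1500 nM to 7500 nM.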

Compound 3, half-maximal inhibitory concentration: > 100000 nM
Compound 3: no number, only a limit; the forecaster's own chance of this, stated with the estimate: 3%; middle value at least 29-fold (1.46 log units) from the limit.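

Compound 3 carries a limit and not a number in this assay: the limit of > 100000 nM in this assay, at which 1 of the 3 values shown sits. At the place on a saturated chain carbon bound to an oxygen on an aromatic ring, 3-fluorophenyl in place of 4-methylphenyl gives an at least 20-fold higher number from compound 2 to compound 3 (1.30 log units; beyond the scatter), and 3-fluorophenyl in place of 2-fluorophenyl gives an at least 32-fold higher number from compound 1 to compound 3 (1.51 log units; beyond the scatter). The earlier pair stayed within the scatter of each other and suggested little dependence on the group at this place, whereas these steps show that it can decide the read-out, and that 2-fluorophenyl and 3-fluorophenyl are not interchangeable here.

The true size of both steps stays open, since compound 3 has only a limit, and the compounds shown give no cause for them. Also open, going by these compounds, is how a plain phenyl or an amine at this place would read.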